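The compounds below may be only part of what the source reports. "The series", "measured", "known", "first", "only" and "open" are said of these compounds alone.

Measured compounds:

- compound 1, `Cc1ccc(S(=O)(=O)N2C/C(=C\c3ccccc3F)C(=O)/C(=C/c3ccccc3F)C2)cc1` — in a functional assay on HepG2 cells (Homo sapiens) for cytotoxicity, read by MTT assay, with a stated time of 24 h (on this read-out higher numbers stand for weaker inhibition and lower numbers for stronger inhibition), compound 1 gives 14200 nM
- compound 2, `O=C1/C(=C/c2ccccc2F)CN(S(=O)(=O)c2ccc(O[N+](=O)[O-])cc2)C/C1=C\c1ccccc1F` — in this assay compound 2 gives 16500 nM
- compound 3, `Cc1ccc(S(=O)(=O)N2C/C(=C\c3ccc(F)cc3)C(=O)/C(=C/c3ccc(F)cc3)C2)cc1` — in this assay compound 3 gives 4500 nM

Compound 1 and compound 2 share a core and differ in one place: nitrooxy in place of methyl on an aromatic carbon. That change gave a 1.2-fold higher number from compound 1 to compound 2 (0.07 log units; within the scatter), so the two values sit within the scatter of each other and no order between them is claimed.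

Compound 3 carries the other core of the series; how its core differs from that of compound 1 is not broken down here. Compound 3 has the lowest number of the three, with compound 1 and compound 2 both beyond the scatter above it.

Compound 4, `O=C1/C(=C/c2ccc(F)cc2)CN(S(=O)(=O)c2ccc(O[N+](=O)[O-])cc2)C/C1=C\c1ccc(F)cc1`, is the unmeasured partner of compound 3, related to it as compound 2 is to compound 1: nitrooxy in place of methyl on an aromatic carbon. The place lines of the two changes agree word for word, so this is the same change, seen once before in the pair compound 1 to compound 2.

Because the earlier instance gave only a 1.2-fold higher number from compound 1 to compound 2 (0.07 log units; within the scatter), the step from compound 3 to compound 4 in this assay is expected to be of the same small size, a 1.2-fold higher number from compound 3 to compound 4 (0.06 log units; within the scatter), essentially flat within the scatter. On that basis compound 4 is estimated to give 5200 nM in this assay, with a likely range from 2500 nM to 11000 nM; the range is wide mainly because the change rests on a single prior pair.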

Compound 4, half-maximal inhibitory concentration: 5400 nM
Estimate against measurement, compound 4: 1.0-fold (0.02 log units) below; the measured number falls inside the stated range.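

In this assay, nitrooxy in place of methyl on the aromatic carbon gives a 1.2-fold higher number from compound 3 to compound 4 (0.08 log units; within the scatter), so on the core of compound 3 this change again stays within the scatter, as it did on the core of compound 1. Set side by side, the two instances of the change agree, and the size of the step carries over from one core to the other in this series: the same change on two cores in this assay, a 1.2-fold higher number (0.07 log units; within the scatter) from compound 1 to compound 2 and a 1.2-fold higher number (0.08 log units; within the scatter) from compound 3 to compound 4, 1.0-fold (0.01 log units) apart, within the scatter of two such steps. This holds for two cores, one change and one read-out only; it does not show that the step would stay this small on any further core or under other assay conditions, and two steps within the scatter give no reason for the agreement and assign no role to the nitrooxy group.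

Open, going by these compounds, is how other groups in the place of methyl, such as an amine, a carboxylic acid or a longer chain, would read on either core, and whether any of them would move the number beyond the scatter. Also open, on these data alone, is whether the same flat step would appear on cores whose fluorine is replaced by another group, such as chlorine or methoxy.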